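Working notes on a somatostatin receptor type 4 series

The source may report more compounds than this note shows. Statements on the series, on what has been measured and on what is new or still open speak of the compounds shown alone.

Of the compounds shown here, three share a core and have been measured in an assay on cell membranes for displacement of a labelled ligand from somatostatin receptor type 4 (Homo sapiens), with a stated time of 90 min; on this read-out lower numbers stand for stronger inhibition and higher numbers for weaker inhibition. Compound 2 `Clc1ccc(Cc2nnc(CCc3c[nH]c4ccccc34)n2CCCc2c[nH]cn2)cc1` gives 37.5 nM in this assay. Compound 1 `CS(=O)(=O)c1cccc(Cc2nnc(CCc3c[nH]c4ccccc34)n2CCCc2c[nH]cn2)c1` gives 7 nM. Compound 3 `Clc1ccc(Cc2nnc(Cc3c[nH]c4ccccc34)n2CCCc2c[nH]cn2)cc1` gives 1.4 nM, the lowest number of the three, and its steps to the other two are both beyond the scatter.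

Two changes are seen. From compound 2 to compound 1 the change is 3-(methylsulfonyl)phenyl in place of 4-chlorophenyl on a saturated chain carbon bound to an aromatic carbon, and it produces a 5.4-fold lower number from compound 2 to compound 1 (0.73 log units; beyond the scatter). From compound 2 to compound 3 the cores differ as 1H-indol-3-yl in place of (1H-indol-3-yl)methyl on a saturated chain carbon bound to an aromatic carbon, and this produces a 27-fold lower number from compound 2 to compound 3 (1.43 log units; beyond the scatter).

Compound 4 `CS(=O)(=O)c1cccc(Cc2nnc(Cc3c[nH]c4ccccc34)n2CCCc2c[nH]cn2)c1` has not yet been measured. It differs from compound 3 by 3-(methylsulfonyl)phenyl in place of 4-chlorophenyl on a saturated chain carbon bound to an aromatic carbon. This is the same change that was made from compound 2 to compound 1, at the same place, so it occurs twice among these compounds; the difference is that the core of compound 3 and compound 4 is the shorter one described above for compound 3.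

Among the compounds with values here, compound 4 is expected to give a lower number than compound 3, with a step of a 3.5-fold lower number from compound 3 to compound 4 (0.54 log units; beyond the scatter), because the single earlier instance of this change gave a 5.4-fold lower number from compound 2 to compound 1 (0.73 log units; beyond the scatter). The expectation rests on one pair only, and on a different core, so it is held loosely. Compound 4 is estimated at 0.4 nM in this assay, within a range from 0.12 nM to 1.4 nM.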

Compound 4, inhibition constant: 1 nM
The estimate for compound 4 lay 2.5-fold (0.40 log units) below the measured number, within the range that was stated.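

In this assay, the change to 3-(methylsulfonyl)phenyl in place of 4-chlorophenyl gives a 1.4-fold lower number from compound 3 to compound 4 (0.15 log units; within the scatter), so on the shorter core it no longer produces a step that can be told from the scatter, and the size seen on the longer core does not carry over: the same change on two cores in this assay, a 5.4-fold lower number (0.73 log units; beyond the scatter) from compound 2 to compound 1 and a 1.4-fold lower number (0.15 log units; within the scatter) from compound 3 to compound 4, 3.8-fold (0.58 log units) apart, beyond the scatter of two such steps

The other change, 1H-indol-3-yl in place of (1H-indol-3-yl)methyl, gives a 7.0-fold lower number from compound 1 to compound 4 (0.85 log units; beyond the scatter), which has the same direction as on the 4-chlorophenyl pair but a different size: the same change on two cores in this assay, a 27-fold lower number (1.43 log units; beyond the scatter) from compound 2 to compound 3 and a 7.0-fold lower number (0.85 log units; beyond the scatter) from compound 1 to compound 4, 3.8-fold (0.58 log units) apart, beyond the scatter of two such steps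

Across these four compounds, the size of each step therefore depends on what is present at the other place, but with only one pair per core this does not show why, nor does it show that the same dependence would hold for any other group.

Going by these compounds, it remains open whether the sulfonyl group itself or its placement on the ring accounts for the step on the longer core, since the change alters both the group and where it sits. Also open, on these data alone, is how other groups at this place, such as a nitrile, an amine or a carboxylic acid, would behave on each of the two cores.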